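Inversion of a chain stereocentre in a des-chloro analogue

A few compounds are considered here, and "the series" means these few. Any claim that something is new, unique, unknown or untested is made for them only; others in the source may bear on it.

Measured compounds:
compound 1, `Cc1cc(Cl)cc(C)c1OC[C@H](C)CN`: 3720 nM
compound 2, `Cc1cc(Cl)cc(C)c1OC[C@@H](C)CN`: 2880 nM
compound 3, `Cc1cccc(C)c1OC[C@H](C)CN`: 23400 nM

In an assay on isolated protein for inhibition of sodium channel protein type 4 subunit alpha (Homo sapiens) (a lower number here means that less compound is needed, a higher number that more compound is needed for the effect), compound 3 gives 23400 nM, the highest of the three numbers recorded; the nearest to it is compound 1, and the step of a 6.3-fold higher number from compound 1 to compound 3 (0.80 log units; beyond the scatter) is a modest one, arising when hydrogen replaces chloro on an aromatic carbon. The furthest is compound 2.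

Compound 4, `Cc1cccc(C)c1OC[C@@H](C)CN`, is the as yet unmeasured partner of compound 3. The change is the two compounds have the same atoms and bonds and differ only in configuration as drawn: 1 of 1 stereo elements differ; a stereocentre at a saturated chain carbon is drawn R in compound 3 and S in compound 4. For the measured compounds named here, one measured step bears directly on this: compounds 1 and 2 are related in the same way, and the fact that compounds 1 and 2 differ only in the configuration as drawn is what makes that step the relevant comparison. That step, a 1.3-fold lower number from compound 1 to compound 2 (0.11 log units; within the scatter), lay within the scatter. On this basis the corresponding inversion in the des-chloro pair is expected to give no change beyond the scatter in this assay, in either direction. Compound 4 is therefore estimated at 20000 nM, with a likely range from 9000 nM to 45000 nM, an expected step of a 1.2-fold lower number from compound 3 to compound 4 (0.07 log units; within the scatter).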

Compound 4, half-maximal effective concentration: 17400 nM
Estimate against measurement, compound 4: 1.1-fold (0.06 log units) above; the range from low to high includes it.
By their numbers in this assay, from the lowest: compounds 2 and 1 (each within the scatter of the next); then compounds 4 and 3 (each within the scatter of the next).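

Inversion of the chain stereocentre gives a 1.3-fold lower number from compound 3 to compound 4 (0.13 log units; within the scatter) in this assay, so the configuration as drawn makes no difference beyond the scatter on the des-chloro core either, and this now holds on both cores shown: the fact that compounds 3 and 4 differ only in the configuration as drawn. Hydrogen in place of chloro, until now read only with the stereocentre drawn R, gives a 6.0-fold higher number from compound 2 to compound 4 (0.78 log units; beyond the scatter) with it drawn S. The size of this step therefore holds across both configurations: the same change on two cores in this assay, a 6.3-fold higher number (0.80 log units; beyond the scatter) from compound 1 to compound 3 and a 6.0-fold higher number (0.78 log units; beyond the scatter) from compound 2 to compound 4, 1.0-fold (0.02 log units) apart, within the scatter of two such steps.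

The compounds shown leave open whether a group other than chloro on that aromatic carbon, such as bromo or methoxy, would shift the number further. They also leave open whether the configuration would still make no difference with such a group, or with a longer chain carrying the amine.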